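Can a methoxy revive compound 3?

A few compounds are considered here, and "the series" means these few. Any claim that something is new, unique, unknown or untested is made for them only; others in the source may bear on it.

In a functional assay on Jurkat cells (Homo sapiens) for antiproliferative activity, read by MTT assay, with a stated time of 72 h (a higher number here means a weaker inhibitor, a lower number a stronger inhibitor), compound 1 `COc1ccc(-c2ncnn2-c2cc(OC)c(OC)c(OC)c2)cc1` gives 50 nM. Compound 2 `COc1cc(-n2ncnc2-c2ccc(Cl)cc2)cc(OC)c1OC` gives > 10000 nM, which is a limit. Compound 3 `COc1cc(-n2ncnc2-c2ccccc2)cc(OC)c1OC` gives > 10000 nM, which is also a limit. Compound 3 therefore stands at the limit of > 10000 nM in this assay, at which 2 of the 3 values shown sit, with no exact number to start from.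

Compound 4 `COc1ccccc1-c1ncnn1-c1cc(OC)c(OC)c(OC)c1` differs from compound 3 in one place: methoxy in place of hydrogen on an aromatic carbon. Its phenyl becomes 2-methoxyphenyl, with methoxy in place of hydrogen, ortho to a large group.

For the measured compounds named here, two measured steps bear on this change. Removing the methoxy gave an at least 200-fold higher number from compound 1 to compound 3 (2.30 log units; beyond the scatter), and chloro in its place gave an at least 200-fold higher number from compound 1 to compound 2 (2.30 log units; beyond the scatter). Both show that a methoxy on this ring can matter greatly. However, the methoxy of compound 1 is not ortho to a large group, so these steps are only a partial guide. A lower number is expected in this assay, but a smaller gain than those steps suggest. The estimated change is an at least 3.3-fold lower number from compound 3 to compound 4 (0.52 log units; beyond the scatter). For compound 4 the estimated value is 3000 nM, with an expected range from 300 nM to 10000 nM.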

Compound 4, half-maximal inhibitory concentration: > 10000 nM
Compound 4 gave a limit, no number; the forecaster's own chance of this, stated with the estimate: 45%; at least 3.3-fold (0.52 log units) between middle value and limit.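

Moving the methoxy from 4-methoxyphenyl to 2-methoxyphenyl gives an at least 200-fold higher number from compound 1 to compound 4 (2.30 log units; beyond the scatter), so the presence of a methoxy on this ring is not enough: where it sits matters greatly. In this assay, compound 4 gives a limit, not a number, and so it offers no exact value to build on: the limit of > 10000 nM in this assay, at which 3 of the 4 values shown sit. The steps from compound 2 and from compound 3 to compound 4 cannot be read, so any effect of the 2-methoxyphenyl relative to those two compounds stays hidden.

For the compounds shown here, compound 1, at 50 nM, remains the only compound here with an exact value. As far as these compounds go, it stays open whether an ethoxy, a hydroxy or an amine in place of its methoxy would keep activity of that order.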